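The source may hold more compounds than are shown below. What is called first, only, known or untested is meant among the compounds shown, and "the series" means these compounds.

Measured so far:
Compound 1 `O=c1nc(N2CC[C@H](c3ccccc3)[C@@H](O)C2)sc2c([N+](=O)[O-])cc(C(F)(F)F)cc12`, in a toxicity assay on HeLa cells (Homo sapiens) for cytotoxicity, read by colorimetric assay, with a stated time of 72 h (a higher number here means that more compound is tolerated, a lower number that less compound is tolerated), compound 1 gives 73100 nM.
Compound 2 `O=c1nc(N2CC[C@@H](c3ccccc3)[C@H](O)C2)sc2c([N+](=O)[O-])cc(C(F)(F)F)cc12`, in this assay compound 2 gives > 93000 nM, which is a limit of the assay and not a number.

Compound 2 therefore stands at the limit of the range shown, the one value of the two at which only a limit is reported (the limit of > 93000 nM in this assay, at which 1 of the 2 values shown sits). Within the data shown here, the single measured step, an at least 1.2-fold higher number from compound 1 to compound 2 (0.10 log units; that floor lies within the scatter), rests on the fact that compounds 1 and 2 differ only in the configuration as drawn and does not reach beyond the scatter at its floor.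

Compound 3 `O=c1nc(N2CC[C@@H](c3ccc(F)cc3)[C@H](O)C2)sc2c([N+](=O)[O-])cc(C(F)(F)F)cc12` differs from compound 2 by fluoro in place of hydrogen on an aromatic carbon. No measured step in the series touches a change of this kind; the only step recorded is the mirror-image pair, whose size is given above, and it carries no information about a substituent on the aromatic ring. With nothing to point the other way, no shift beyond the scatter is expected in this assay, so the step of an at least 1.0-fold lower number from compound 2 to compound 3 (0.01 log units; that floor lies within the scatter) is estimated as flat. For compound 3 the expected value in this assay is 90000 nM, within 40000 nM to 200000 nM, with a fair chance that again only a limit is reported.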

Compound 3, half-maximal cytotoxic concentration: 68400 nM
The estimate for compound 3 lay 1.3-fold (0.12 log units) above the measured number, within the range that was stated.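

Phenyl to 4-fluorophenyl is the first change in the series that touches the aromatic ring and not the configuration, and in this assay compound 3 gives 68400 nM, a number and not a limit. Compound 2 gives > 93000 nM, which is a limit of the assay and not a number. The change of hydrogen to fluoro at this aromatic carbon, para to a large group, therefore has only a floor, an at least 1.3-fold lower number from compound 2 to compound 3 (0.13 log units; that floor lies within the scatter), so whether the real step goes beyond the scatter cannot be read, and the size of the step stays bounded on one side only: the limit of > 93000 nM in this assay, at which 1 of the 3 values shown sits.

Open, going by these compounds, is whether a larger group at the same place, such as chloro, methoxy or an amine, would move the number in this assay beyond the scatter, and whether a carboxylic acid there would do so. Also open, on these data alone, is whether the same change of hydrogen to fluoro gives a comparable step on the mirror-image configuration of compound 1.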